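A few compounds are considered here, and "the series" means these few. Any claim that something is new, unique, unknown or untested is made for them only; others in the source may bear on it.

Measured in a functional assay on the whole organism for inhibition, with Nicotiana tabacum as the target; a higher number here means a weaker inhibitor, a lower number a stronger inhibitor:

- compound 1 `CCc1ccc(Nc2[nH]c(C)nc3nccc2-3)cc1`: 214000000 nM
- compound 2 `Cc1nc(Nc2ccc(N)cc2)c2cc[nH]c2n1`: 195000000 nM
- compound 3 `COc1ccc(Nc2[nH]c(C)nc3nccc2-3)cc1`: 661000000 nM

Compound 3 stands at the highest of the three numbers in this assay; compound 1 gives the nearest number and compound 2 the furthest, both lower than that of compound 3 and both beyond the scatter. Within the data shown here, the single one-change step recorded is a 3.1-fold higher number from compound 1 to compound 3 (0.49 log units; beyond the scatter), methoxy in place of ethyl on an aromatic carbon. Between compound 2 and compound 3 no single step is defined; the two values simply show compound 2 lower.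

Compound 4 `CC(=O)c1ccc(Nc2[nH]c(C)nc3nccc2-3)cc1` differs from compound 3 by acetyl in place of methoxy on an aromatic carbon. Among the measured compounds shown here, no measured step puts acetyl into this position, so the only relevant comparison is the recorded methoxy step, which was modest. Acetyl is therefore expected to move the number in this assay by no more than a modest amount, direction uncertain, most likely back toward the rest of the series; the expected step is a 1.7-fold lower number from compound 3 to compound 4 (0.22 log units; within the scatter). For compound 4 the estimate in this assay is 400000000 nM, within a range from 130000000 nM to 1300000000 nM.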

Compound 4, half-maximal inhibitory concentration: 646000000 nM
Beside the measured number, compound 4's estimate is 1.6-fold (0.21 log units) below it; the range from low to high includes it.
By their numbers in this assay, from the lowest: compounds 2 and 1 (each within the scatter of the next); then compounds 4 and 3 (each within the scatter of the next).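

In this assay, acetyl in place of methoxy on an aromatic carbon, para to a large group, gives a 1.0-fold lower number from compound 3 to compound 4 (0.01 log units; within the scatter) and so leaves the two groups indistinguishable at this position. Acetyl in place of ethyl gives a 3.0-fold higher number from compound 1 to compound 4 (0.48 log units; beyond the scatter) and, set beside a 3.1-fold higher number from compound 1 to compound 3 (0.49 log units; beyond the scatter) for methoxy, shows that the separation from ethyl is not confined to methoxy: across compound 1, compound 3 and compound 4, both oxygen-bearing groups stand apart from ethyl by similar steps. No measurement bears on the reason for this shared separation.

From the compounds shown here alone, whether a carboxylic acid or a longer alkyl chain at this position would stay with methoxy and acetyl or fall with ethyl remains open. The place of a hydroxyl or a fluorine on this scale is equally unsettled.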